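Replacing the imidazole chain of compound 3 with a triazole diol

This account rests on a few compounds, and the source may have more. Where it says the series, first, only, none or still open, it means among the compounds named here.

In a functional assay on HCT-116 cells (Homo sapiens) for cytotoxicity, read by MTT assay, with a stated time of 72 h (on this read-out higher numbers stand for weaker inhibition and lower numbers for stronger inhibition), compound 3 (`O=C1c2c[n+]([O-])c3ccccc3c2C(=O)c2c1c1ccccc1n2CCCCn1ccnc1`) gives 240 nM and so lies within the scatter of compound 1 (`CN(C)CCCCCn1c2c(c3ccccc31)C(=O)c1c[n+]([O-])c3ccccc3c1C2=O`) at 470 nM on the same read-out. Compound 2 (`O=C1c2c[n+]([O-])c3ccccc3c2C(=O)c2c1c1ccccc1n2Cc1cn([C@H]2O[C@H](CO)[C@@H](O)[C@H]2O)nn1`) reads 710 nM by comparison, a higher number that stands beyond the scatter from compound 3.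

The next structure is compound 4 (`O=C1c2c[n+]([O-])c3ccccc3c2C(=O)c2c1c1ccccc1n2Cc1cn(C[C@H](O)CO)nn1`). It carries 1-(2,3-dihydroxypropyl)-1H-1,2,3-triazol-4-yl in place of 3-(1H-imidazol-1-yl)propyl on a saturated chain carbon bound to an aromatic nitrogen.

Within the data shown here, only one measured step exists in this set, a 2.0-fold lower number from compound 1 to compound 3 (0.29 log units; within the scatter) and it exchanges (dimethylamino)methyl for 1H-imidazol-1-yl, so it offers no direct guide to a triazole. Among the measured compounds shown here, the closer precedent is compound 2 at 710 nM since it also holds a triazole on that chain, although only this one compound supports the comparison. A move toward a higher number, probably just beyond the scatter, is therefore expected in this assay for this exchange. The estimated step is a 2.5-fold higher number from compound 3 to compound 4 (0.40 log units; beyond the scatter) in that direction. Compound 4 is expected at about 600 nM with an estimated range from 250 nM to 1400 nM in this estimate.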

Compound 4, half-maximal inhibitory concentration: 400 nM
For compound 4 the middle estimate is 1.5-fold (0.18 log units) above the measured one; the range from low to high includes it.
By their numbers in this assay, from the lowest: compounds 3, 4, 1 and 2 (each within the scatter of the next, the first and the last beyond it).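

In this assay, placing 1-(2,3-dihydroxypropyl)-1H-1,2,3-triazol-4-yl on the saturated chain carbon bound to an aromatic nitrogen gives a 1.7-fold higher number from compound 3 to compound 4 (0.22 log units; within the scatter), and the comparison with the 4-(dimethylamino)butyl chain gives a 1.2-fold lower number from compound 1 to compound 4 (0.07 log units; within the scatter), so a side chain with neither an imidazole nor a dimethylamino group still reads alongside those that carry one. On the aromatic nitrogen of the triazole, 2,3-dihydroxypropyl in place of 3,4-dihydroxy-5-(hydroxymethyl)oxolan-2-yl gives a 1.8-fold lower number from compound 2 to compound 4 (0.25 log units; within the scatter), which places compound 4 within the scatter of compound 2 as well as compound 3, even though those two lie beyond the scatter of each other. Nothing available accounts for why these different side chains read so closely in this cytotoxicity measurement.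

The compounds shown leave open whether the hydroxyl groups of compound 4 contribute at all, a question that a triazole bearing a plain propyl chain or a carboxylic acid would address. They also leave open how the mirror-image form of the 2,3-dihydroxypropyl group would read, and whether a longer chain between the triazole and the core would move the number beyond the scatter.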